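Replacing amino with nitro on compound 1

This account rests on a few compounds, and the source may have more. Where it says the series, first, only, none or still open, it means among the compounds named here.

Measured in a functional assay on K562 cells (Homo sapiens) for antiproliferative activity, read by MTT assay, with a stated time of 72 h (a lower number here means a stronger inhibitor, a higher number a weaker inhibitor), so far
compound 1 `COc1cc(-c2ncnn2-c2cccc(N)c2)cc(OC)c1OC` gives > 10000 nM
compound 2 `COc1cc(-c2ncnn2-c2ccc(N)cc2)cc(OC)c1OC` gives > 10000 nM
compound 3 `COc1ccc(-n2ncnc2-c2cc(OC)c(OC)c(OC)c2)cc1` gives 3600 nM

Compound 1 at > 10000 nM holds a limit of the assay and not a number. Compound 2 at > 10000 nM holds the same kind of limit. Compound 3 at 3600 nM is the only one of the three with a true number.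

The change in view leads to compound 4 `COc1cc(-c2ncnn2-c2cccc([N+](=O)[O-])c2)cc(OC)c1OC` and is nitro in place of amino on an aromatic carbon. Among the measured steps, a step that the two limits leave unreadable from compound 1 to compound 2 gives no guidance. Two others bear on the change, since each removes an amino group: an at least 2.7-fold lower number from compound 1 to compound 3 (0.44 log units; beyond the scatter) and an at least 2.7-fold lower number from compound 2 to compound 3 (0.44 log units; beyond the scatter) are of equal size. The second is the closer in kind, as methoxy replaces amino on an aromatic carbon, but it starts from the 4-aminophenyl compound. Neither step involves nitro, so the evidence is indirect.

In this assay a modest move towards a lower number is therefore expected, though another limit result is about as likely. The expected step is an at least 1.4-fold lower number from compound 1 to compound 4 (0.15 log units; that floor lies within the scatter) and remains an estimate. For compound 4 the estimated value is 7000 nM with an expected range from 2500 nM to 20000 nM as its span.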

Compound 4, half-maximal inhibitory concentration: > 10000 nM
Compound 4: a limit, no number (the forecaster's own chance of this, stated with the estimate: 45%); middle value at least 1.4-fold (0.15 log units) away from the limit.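

In this assay, for the compounds shown here, compound 4 gives a limit and not a number, as compound 1 does, so no step between the two can be read. The result joins a shared limit: the limit of > 10000 nM in this assay, at which 3 of the 4 values shown sit.

Still open, on these data alone, is whether nitro and amino on the shared core differ at all in this assay, and in which direction.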